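The source may report more compounds than this note shows. Statements on the series, on what has been measured and on what is new or still open speak of the compounds shown alone.

Compound 1, `CC(C)COc1nc(C(C)(C)C)ccc1CNC(=O)C(C)c1ccc(NS(C)(=O)=O)c(F)c1`, gives 0.6 nM in an assay on cells for antagonist activity at transient receptor potential cation channel subfamily V member 1 (Homo sapiens), read by FLIPR and calcium flux, with a stated time of 6 min; a lower number here means a stronger inhibitor, a higher number a weaker inhibitor.
Compound 2, `CC(C)CCOc1nc(C(C)(C)C)ccc1CNC(=O)C(C)c1ccc(NS(C)(=O)=O)c(F)c1`, gives 0.8 nM in this assay.
Compound 3, `CC(C(=O)NCc1ccc(C(C)(C)C)nc1SCCCN1CCCC1)c1ccc(NS(C)(=O)=O)c(F)c1`, gives 17.1 nM in this assay.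

Compound 2 stands second highest of these three numbers; its nearest neighbour is compound 1, with a 1.3-fold higher number from compound 1 to compound 2 (0.12 log units; within the scatter), and its furthest is compound 3, with a 21-fold higher number from compound 2 to compound 3 (1.33 log units; beyond the scatter).

Compound 4, `CC(C(=O)NCc1ccc(C(C)(C)C)nc1SCc1ccccc1)c1ccc(NS(C)(=O)=O)c(F)c1`, is not yet measured. Its change from compound 2 is benzylsulfanyl in place of isopentyloxy on an aromatic carbon.

For the measured compounds named here, the steps that bear on it are those that swap the ether for a thioether on the same aromatic carbon: a 21-fold higher number from compound 2 to compound 3 (1.33 log units; beyond the scatter) and a 29-fold higher number from compound 1 to compound 3 (1.45 log units; beyond the scatter), both large. In those steps the entering group was the (3-(pyrrolidin-1-yl)propyl)sulfanyl chain, whereas here benzylsulfanyl enters, so how much of that loss belongs to the sulfur alone is not shown. A loss in this assay is therefore expected for compound 4, probably smaller than in those steps, amounting to a 6.3-fold higher number from compound 2 to compound 4 (0.80 log units; beyond the scatter). Compound 4 is estimated at 5 nM, within 1.5 nM to 20 nM.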

Compound 4, inhibition constant: 4 nM
Beside the measured number, compound 4's estimate is 1.3-fold (0.10 log units) above it, and the stated range covers the measured number.
By their numbers in this assay, from the lowest: compounds 1 and 2 (each within the scatter of the next); then compound 4; then compound 3.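

In this assay, a thioether without the pyrrolidine chain loses much less than compound 3 did, with modest steps against both ethers (a 5.0-fold higher number from compound 2 to compound 4 (0.70 log units; beyond the scatter); a 6.7-fold higher number from compound 1 to compound 4 (0.82 log units; beyond the scatter)). The two thioethers also differ beyond the scatter (a 4.3-fold lower number from compound 3 to compound 4 (0.63 log units; beyond the scatter)), so the sulfur alone cannot set the number at this aromatic carbon, and what it carries matters as well. No measurement shown here explains these shifts.

As far as these compounds go, how much of the remaining loss belongs to the sulfur stays open, as compound 2 and compound 4 differ in both the linking atom and the chain. A benzyloxy group on the same carbon, or an isopentylsulfanyl group, would separate those two changes, and a 3-(pyrrolidin-1-yl)propoxy chain would test the amine chain without sulfur.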